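The source may hold more compounds than are shown below. What is called first, only, known or untested is meant among the compounds shown, and "the series" means these compounds.

In a functional assay on K562 cells (Homo sapiens), read by MTT assay, with a stated time of 72 h (a lower number here means a stronger inhibitor, a higher number a weaker inhibitor), compound 1 `CNc1ncnc2c1c(-c1cc3ccccc3o1)cn2[C@@H]1O[C@H](CO)[C@@H](O)[C@H]1O` gives > 20000 nM, which is a limit of the assay and not a number. Compound 2 `C#Cc1cn([C@@H]2O[C@H](CO)[C@@H](O)[C@H]2O)c2ncnc(N(C)C)c12` gives a measured 110 nM. Compound 3 `O=c1[nH]cnc2c1c(-c1ccccc1)cn2[C@@H]1O[C@H](CO)[C@@H](O)[C@H]1O` gives > 20000 nM, again a limit. It therefore has no exact position and stands with one other compound at the limit of > 20000 nM in this assay, at which 2 of the 3 values shown sit.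

Compound 4 `O=c1[nH]cnc2c1c(-c1cc3ccccc3o1)cn2[C@@H]1O[C@H](CO)[C@@H](O)[C@H]1O` carries 1-benzofuran-2-yl in place of the phenyl of compound 3, on an aromatic carbon: 1-benzofuran-2-yl in place of phenyl on an aromatic carbon. The same 1-benzofuran-2-yl group is carried by compound 1, which reads > 20000 nM, so no gain is expected from it.

The expected a number no higher from compound 3 to compound 4 (the limit leaves the size open) in this assay is none beyond the scatter, in neither direction, and a reading at the limit is likely. For compound 4 the estimate is 20000 nM, with an expected range of 10000 nM to 30000 nM.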

Compound 4, half-maximal inhibitory concentration: > 20000 nM
Compound 4 was reported as a limit; the forecaster's own chance of this, stated with the estimate: 85%; the middle value lies on the limit itself.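

For the compounds shown here, compound 3 and compound 4 both read as limits and not as numbers, so no step between them can be read: the limit of > 20000 nM in this assay, at which 3 of the 4 values shown sit. The compounds shown leave open whether phenyl and 1-benzofuran-2-yl differ at all on the shared core.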